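Lengthening a Chain Across Two Related Cores

A few compounds are considered here, and "the series" means these few. Any claim that something is new, unique, unknown or untested is made for them only; others in the source may bear on it.

Compound 1 `Cc1nn(C)c2c1C(c1ccccc1)=NCC(=O)N2` and compound 2 `CCc1nn(C)c2c1C(c1ccccc1)=NCC(=O)N2` share one core and differ in a single place: methyl in place of hydrogen on a saturated chain carbon bound to an aromatic carbon. In a functional assay on the whole organism with Rattus norvegicus as the target (a lower number here means that less compound is needed, a higher number that more compound is needed for the effect), compound 1 gives 16 mg/kg, and compound 2 gives 8 mg/kg, so that a 2.0-fold lower number from compound 1 to compound 2 (0.30 log units; within the scatter). Compound 3 `CCCc1nn(C)c2c1C(c1ccccc1Cl)=NCC(=O)N2` is built on a second core; the difference between the two cores is not broken down here. In this assay compound 3 gives 250 mg/kg, the highest of the three values and beyond the scatter from both of the others.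

Compound 4 `CCCCc1nn(C)c2c1C(c1ccccc1Cl)=NCC(=O)N2` has not yet been measured. It differs from compound 3 by methyl in place of hydrogen on a saturated chain carbon, three bonds along the chain from an aromatic carbon. This is the same kind of change as that between compound 1 and compound 2, but not the same: there the methyl entered on a saturated chain carbon bound to an aromatic carbon, here on a saturated chain carbon, three bonds along the chain from an aromatic carbon, and the core is a different one. Because the earlier step of a 2.0-fold lower number from compound 1 to compound 2 (0.30 log units; within the scatter) stayed within the scatter, the step of a 1.3-fold lower number from compound 3 to compound 4 (0.10 log units; within the scatter) is expected to be small as well. For compound 4 the estimated value is 200 mg/kg, expected between 60 mg/kg and 600 mg/kg.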

Compound 4, minimum effective dose: > 500 mg/kg
Compound 4: no number, only a limit; the forecaster's own chance of this, stated with the estimate: 15%; middle value at least 2.5-fold (0.39 log units) away from the limit.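

In this assay the added methyl gives an at least 2.0-fold higher number from compound 3 to compound 4 (0.30 log units; that floor lies within the scatter), a step that rests on a limit of the assay for compound 4 and not on a number: the limit of > 500 mg/kg in this assay, at which 1 of the 4 values shown sits. Set beside the earlier step, the same change does not carry over unchanged from one core to the other in these two pairs: the same change on two cores in this assay, a 2.0-fold lower number (0.30 log units; within the scatter) from compound 1 to compound 2 and an at least 2.0-fold higher number (0.30 log units; that floor lies within the scatter) from compound 3 to compound 4, at least 4.0-fold (0.60 log units) apart, beyond the scatter of two such steps This does not show why the steps part, since the pairs differ in the core and also in the place of the methyl, on a saturated chain carbon bound to an aromatic carbon in one and three bonds along the chain from an aromatic carbon in the other, and the true size of the second step remains unknown.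

The compounds shown leave open how propyl and butyl chains behave on the core of compound 1, and how ethyl behaves on the core of compound 3. Also open, on these data alone, is what a pentyl chain, or an amine or a carboxylic acid at the end of the chain, would give on either core.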